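The source may hold more compounds than are shown below. What is called first, only, known or untested is meant among the compounds shown, and "the series" means these compounds.

Measured so far:
- compound 1, `CCC(=O)Nc1ccc(S(=O)(=O)Oc2ccccc2I)cc1`: 11000 nM
- compound 2, `CCCC(=O)Nc1ccc(S(=O)(=O)Oc2ccccc2I)cc1`: 11000 nM
- compound 3, `CC(C)(C)C(=O)Nc1ccc(S(=O)(=O)Oc2ccccc2I)cc1`: 9500 nM

These three compounds share one core and differ only in the group on the carbonyl carbon of the amide. In a functional assay on HT-29 cells (Homo sapiens) for antiproliferative activity, read by sulforhodamine B assay, with a stated time of 48 h (a lower number here means a stronger inhibitor, a higher number a weaker inhibitor), compound 3 gives the lowest of the three numbers, yet its gaps to the other two are small: a 1.2-fold lower number from compound 1 to compound 3 (0.06 log units; within the scatter) and a 1.2-fold lower number from compound 2 to compound 3 (0.06 log units; within the scatter) both lie inside the usual scatter, so no ordering among compound 1, compound 2 and compound 3 can be claimed. Likewise no change at the digits printed from compound 1 to compound 2 (within the scatter) shows nothing.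

Compound 4, `O=C(CCl)Nc1ccc(S(=O)(=O)Oc2ccccc2I)cc1`, is the next member: chloromethyl in place of tert-butyl on a carbonyl carbon. Going by the values given here, the steps that bear on this change are the two that also swapped the group on the same carbonyl carbon, a 1.2-fold lower number from compound 1 to compound 3 (0.06 log units; within the scatter) and a 1.2-fold lower number from compound 2 to compound 3 (0.06 log units; within the scatter); both were flat. Among the compounds with values here, every swap tried at this position so far has left this assay unchanged, and nothing among the measured compounds points to a different outcome for a chloromethyl group, though none of them carried a chlorine, so the expectation rests on a narrow base.

Compound 4 is therefore expected to show no step beyond the scatter, with no change at the digits printed from compound 3 to compound 4 (within the scatter) as the estimated change. For compound 4 the estimate in this assay is 9500 nM, with a range from 3000 nM to 30000 nM.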

Compound 4, half-maximal inhibitory concentration: 4100 nM
Estimate against measurement, compound 4: 2.3-fold (0.36 log units) above; the range from low to high includes it.
By their numbers in this assay, from the lowest: compound 4; then compounds 3, 1 and 2 (each within the scatter of the next).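

At this carbonyl carbon, ethyl, propyl and tert-butyl gave numbers within the scatter of one another in this assay, but chloromethyl does not fit with them: the result shows a 2.3-fold lower number from compound 3 to compound 4 (0.36 log units; beyond the scatter) together with a 2.7-fold lower number from compound 1 to compound 4 (0.43 log units; beyond the scatter) and a 2.7-fold lower number from compound 2 to compound 4 (0.43 log units; beyond the scatter) as steps beyond the scatter, each of them modest. This is the first sign that the position can respond at all, and it makes compound 4 the strongest inhibitor of the four shown, with every step to the others beyond the scatter. Going by these compounds alone, still, the change does two things at once, bringing in a chlorine and replacing each larger group with one that carries fewer carbons, so the single step from tert-butyl cannot say which of the two matters.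

Going by these compounds, a plain methyl group, a bromomethyl group or a dichloromethyl group on the same carbonyl carbon would begin to pull those two apart, and whether any such group goes further than chloromethyl remains open. The data shown give no measurement that bears on why the number falls with this change.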